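The compounds below may be only part of what the source reports. "The series", "measured", "known", "first", "only" and "open" are said of these compounds alone.

Measured in a functional assay on HeLa cells (Homo sapiens) for inhibition, read by trypan blue exclusion, with a stated time of 72 h; on this read-out lower numbers stand for stronger inhibition of growth and higher numbers for weaker inhibition of growth:
compound 1, `COc1ccc2c(c1)c(C)c(-c1ccc(OC)c(OC)c1)n2CCCCOc1ccccc1`: > 20000 nM
compound 2, `CCCn1c(-c2ccc(O)c(O)c2)c(C)c2cc(O)ccc21`: > 20000 nM
compound 3, `Cc1c(-c2ccc(O)cc2)[nH]c2ccccc12`: > 20000 nM

The value of compound 1 is a limit of this assay, not a number. The value of compound 2 is likewise a limit. The value of compound 3 is a limit too. Compound 2 therefore stands at the limit of > 20000 nM in this assay, at which 3 of the 3 values shown sit, and no order among the three can be read. Compound 4, `Cc1c(-c2ccc(O)c(O)c2)n(CCCOc2ccccc2)c2ccc(O)cc12`, is still to be measured. It differs from compound 2 by phenoxy in place of hydrogen on a saturated chain carbon, three bonds along the chain from an aromatic nitrogen. For the measured compounds named here, no step between measured compounds is available. Compound 1, which also bears a phenoxy on a saturated chain carbon, sits at the limit, so nothing in the data points to a gain. The step from compound 2 to compound 4 is expected to be a step that the limit leaves unreadable from compound 2 to compound 4, nothing beyond the scatter. Compound 4 is expected at 30000 nM, within 10000 nM to 100000 nM, most likely again reported only as a limit.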

Compound 4, concentration for 50% growth inhibition: 18000 nM
The estimate for compound 4 lay 1.7-fold (0.22 log units) above the measured number, within the range that was stated.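

In this assay, compound 4, at 18000 nM, is the only compound shown that gives a number rather than a limit. Phenoxy in place of hydrogen on a saturated chain carbon, three bonds along the chain from an aromatic nitrogen, gives an at least 1.1-fold lower number from compound 2 to compound 4 (0.04 log units; that floor lies within the scatter). That step is only a floor, and no gain can be claimed from it, because compound 2 sits at a limit: the limit of > 20000 nM in this assay, at which 3 of the 4 values shown sit.

On these data alone, the true distance between these two values remains open. So does whether an amine or a carboxylic acid in place of the phenoxy, or a longer chain, would change the number.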